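The compounds below may be only part of what the source reports. "The series", "measured", "known", "first", "only" and "open" are said of these compounds alone.

Measured in an ADME assay on microsomes from liver (Homo sapiens) for metabolic stability, read by LC-MS, using NADPH, with a stated time of 10 min, tested at 10 uM; a higher number here means that the compound lasts longer, a lower number that the compound disappears faster:
- compound 1 `N#Cc1ccnc(Oc2nn(C3CCC3)c3ncnc(N)c23)c1`: 2.35 h
- compound 2 `Nc1ncnc2c1c(Oc1cc(C(F)(F)F)ccn1)nn2[C@H]1CC[C@@H](N)CC1`: > 2.41 h, a limit of the assay and not a number
- compound 3 `Nc1ncnc2c1c(Oc1cc(C(F)(F)F)ccn1)nn2C1CCC1`: 1.02 h

Compound 1 holds the higher of the two actual numbers, and the gap to the only other one is a 2.3-fold lower number from compound 1 to compound 3 (0.36 log units; beyond the scatter). The third result is the limit of > 2.41 h in this assay, at which 1 of the 3 values shown sits, so it cannot be ranked exactly.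

Next in line is compound 4 `CC(C)(C)n1nc(Oc2cc(C#N)ccn2)c2c(N)ncnc21`, which keeps the core of compound 1 and its nitrile-bearing side. The change is tert-butyl in place of cyclobutyl on an aromatic nitrogen.

Two measured steps offer guidance. The swap on an aromatic carbon, a 2.3-fold lower number from compound 1 to compound 3 (0.36 log units; beyond the scatter), lies elsewhere in the molecule and bears only indirectly. The closer precedent is the swap on an aromatic nitrogen, an at least 2.3-fold lower number from compound 2 to compound 3 (0.37 log units; beyond the scatter), but there 4-aminocyclohexyl is exchanged, a much larger change than the one here. For the measured compounds named here, no measured step compares tert-butyl with cyclobutyl.

In this assay, no step beyond the scatter is therefore expected, although a modest one in either direction remains possible. The expected change is a 1.2-fold lower number from compound 1 to compound 4 (0.07 log units; within the scatter). For compound 4 the estimated half-life is 2 h, with an expected range of 1 h to 3.2 h.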

Compound 4, half-life: > 2.41 h
Compound 4 ended at the assay's limit; the forecaster's own chance of this, stated with the estimate: 30%; middle value at least 1.2-fold (0.08 log units) from the limit.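

In this assay, compound 4 gives > 2.41 h, which is a limit of the assay and not a number. The step reads an at least 1.0-fold higher number from compound 1 to compound 4 (0.01 log units; that floor lies within the scatter), so only a floor is known, and it shows that on this aromatic nitrogen, with the nitrile side kept, the cyclobutyl ring can give way to tert-butyl, which has no ring and the same count of heavy atoms, without any loss beyond the scatter. The earlier compounds showed only cyclobutyl against 4-aminocyclohexyl, and any real gain from tert-butyl over cyclobutyl stays hidden, because compound 4 ended at the ceiling: the limit of > 2.41 h in this assay, at which 2 of the 4 values shown sit.

Still open, going by these compounds, is whether tert-butyl keeps this standing when trifluoromethyl replaces the nitrile, the change that gave a 2.3-fold lower number from compound 1 to compound 3 (0.36 log units; beyond the scatter) on the cyclobutyl series. The compounds shown also leave open how an isopropyl group, a cyclopentyl ring or a longer carbon chain would read on the same aromatic nitrogen, and a shorter incubation or lower ceiling-free read-out would be needed to place compound 4 on a number.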